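A few compounds are considered here, and "the series" means these few. Any claim that something is new, unique, unknown or untested is made for them only; others in the source may bear on it.

Measured compounds in a functional assay on DU-145 cells (Homo sapiens) for cytotoxicity, read by MTT assay, with a stated time of 48 h; a higher number here means a weaker inhibitor, a lower number a stronger inhibitor:
compound 1, `CCOC(=O)c1c(-c2c(Cl)c3ccccc3oc2=O)nn(-c2ccccc2)c1C(=O)OCC`, gives 48000 nM
compound 2, `CCOC(=O)c1c(-c2c(Cl)c3ccccc3oc2=O)nn(-c2cccc(C)c2)c1C(=O)OCC`, gives 32000 nM
compound 3, `CCOC(=O)c1c(-c2c(Cl)c3cc(C)ccc3oc2=O)nn(-c2ccccc2)c1C(=O)OCC`, gives 50000 nM

The three numbers cannot be told apart: a 1.0-fold higher number from compound 1 to compound 3 (0.02 log units; within the scatter), and compound 2 lies no further from compound 3. Compound 4, `CCOC(=O)c1c(-c2c(Cl)c3cc(C)ccc3oc2=O)nn(-c2cccc(C)c2)c1C(=O)OCC`, is compound 3 with methyl in place of hydrogen on an aromatic carbon. The same change, phenyl to 3-methylphenyl, gave a 1.5-fold lower number from compound 1 to compound 2 (0.18 log units; within the scatter), and the other methyl gave a 1.0-fold higher number from compound 1 to compound 3 (0.02 log units; within the scatter); neither left the scatter. Both bear directly on the present step, and nothing seen so far suggests a move beyond the scatter. In this assay a slight downward drift at most is expected for compound 4, a 1.4-fold lower number from compound 3 to compound 4 (0.14 log units; within the scatter). The expected value for compound 4 is 36000 nM, with a range of 18000 nM to 72000 nM.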

Compound 4, half-maximal inhibitory concentration: 103000 nM
For compound 4 the middle estimate is 2.9-fold (0.46 log units) below the measured one, outside the stated range (above it).
By their numbers in this assay, from the lowest: compounds 2, 1 and 3 (each within the scatter of the next); then compound 4.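

In this assay the change from phenyl to 3-methylphenyl does not behave alike on the two cores. With a methyl already on the core, it gives a 2.1-fold higher number from compound 3 to compound 4 (0.31 log units; beyond the scatter), so the two methyl groups do not simply add: the same change on two cores in this assay, a 1.5-fold lower number (0.18 log units; within the scatter) from compound 1 to compound 2 and a 2.1-fold higher number (0.31 log units; beyond the scatter) from compound 3 to compound 4, 3.1-fold (0.49 log units) apart, beyond the scatter of two such steps Read the other way, the methyl on the core, silent alongside plain phenyl, gives a 3.2-fold higher number from compound 2 to compound 4 (0.51 log units; beyond the scatter) alongside 3-methylphenyl: the same change on two cores in this assay, a 1.0-fold higher number (0.02 log units; within the scatter) from compound 1 to compound 3 and a 3.2-fold higher number (0.51 log units; beyond the scatter) from compound 2 to compound 4, 3.1-fold (0.49 log units) apart, beyond the scatter of two such steps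

As far as these compounds go, whether this dependence on the partner group extends beyond methyl remains open. An amine or a longer chain on the same aromatic carbon could test it.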